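Bromo for chloro on a second core: a parallel step

The compounds below may be only part of what the source reports. "The series", "measured", "known", "first", "only" and "open" are said of these compounds alone.

In a functional assay on SW 1116 cells (Homo sapiens) for antiproliferative activity, read by MTT assay, with a stated time of 48 h (on this read-out lower numbers stand for stronger inhibition and higher numbers for weaker inhibition), compound 1 `Clc1ccc(CSc2nnc(-c3cnccn3)o2)cc1` gives 17300 nM. Compound 2 `Brc1ccc(CSc2nnc(-c3cnccn3)o2)cc1` carries bromo in place of chloro on an aromatic carbon, and in this assay compound 2 gives 14400 nM, so that a 1.2-fold lower number from compound 1 to compound 2 (0.08 log units; within the scatter). Compound 3 `Clc1ccc(CSc2nnc(-c3cnccn3)s2)cc1` rests on a different core; the difference between the two cores is not broken down here. In this assay compound 3 gives 4770 nM, the lowest of the three numbers and beyond the scatter from both compound 1 and compound 2. Compound 4 `Brc1ccc(CSc2nnc(-c3cnccn3)s2)cc1` is related to compound 3 by the same change that takes compound 1 to compound 2: bromo in place of chloro on an aromatic carbon, at a place described in the same words for both pairs. On the core of compound 1 this change moved the number only within the scatter, so the step is expected to be small again, namely a 1.2-fold lower number from compound 3 to compound 4 (0.08 log units; within the scatter), because the earlier step was a 1.2-fold lower number from compound 1 to compound 2 (0.08 log units; within the scatter). Compound 4 is therefore expected to give about 4000 nM, with a plausible range from 2000 nM to 8000 nM.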

Compound 4, half-maximal inhibitory concentration: 1470 nM
The estimate for compound 4 lay 2.7-fold (0.43 log units) above the measured number; the measured number lies below the stated range.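

In this assay, bromo in place of chloro on the second core gave a 3.2-fold lower number from compound 3 to compound 4 (0.51 log units; beyond the scatter), so the small step seen on the core of compound 1 did not carry over in size. The two steps differ, one staying within the scatter and the other going beyond it: the same change on two cores in this assay, a 1.2-fold lower number (0.08 log units; within the scatter) from compound 1 to compound 2 and a 3.2-fold lower number (0.51 log units; beyond the scatter) from compound 3 to compound 4, 2.7-fold (0.43 log units) apart, beyond the scatter of two such steps. This shows that, across these two pairs, the size of the step depends on the core on which the change is made, but it does not show which feature of the cores accounts for the gap, and two pairs give no rule for any further core.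

The compounds shown leave open whether fluoro, iodo, a methoxy group or an amine in the same place on the six-membered aromatic ring would also respond differently on the two cores. They also leave open whether a longer chain in place of the one that carries this ring would preserve the gap between the two steps.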